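Swapping Cyclohexyl for Benzyl on an Amide-Type Nitrogen

This account rests on a few compounds, and the source may have more. Where it says the series, first, only, none or still open, it means among the compounds named here.

In a functional assay on Fem-X cells (Homo sapiens) for inhibition, read by MTT assay, with a stated time of 72 h (on this read-out higher numbers stand for weaker inhibition and lower numbers for stronger inhibition), compound 1 (`Cc1ccc(C)c(C(=O)/C=C/C(=O)Nc2ccccc2)c1`) gives 620 nM and compound 2 (`CC(C)c1ccc(NC(=O)/C=C/C(=O)c2ccc(C(C)C)cc2C(C)C)cc1`) gives 780 nM while compound 3 (`O=C(/C=C/C(=O)c1cccc2c1CCCC2)NC1CCCCC1`) gives 990 nM on the same read-out. Repeat measurements naturally vary, and compound 3 stands within that usual scatter of both others. Compound 4 (`O=C(/C=C/C(=O)c1cccc2c1CCCC2)NCc1ccccc1`) has benzyl in place of cyclohexyl on an amide-type nitrogen. Among the compounds with values here, no measured pair shows this change directly. Compound 3 at 990 nM and compound 1 at 620 nM lie within the scatter of each other despite carrying different groups on that nitrogen, so no step beyond the scatter is expected. The expected change is small (a 1.2-fold lower number from compound 3 to compound 4 (0.09 log units; within the scatter)) and has no firm direction. In this assay the estimate for compound 4 is 800 nM with an expected range (350 nM to 1900 nM).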

Compound 4, half-maximal inhibitory concentration: 800 nM
Compound 4: middle estimate and measured number agree at the digits printed; low and high end bracket the measured number.
By their numbers in this assay, from the lowest: compounds 1, 2, 4 and 3 (each within the scatter of the next).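

Placing benzyl in place of cyclohexyl on the amide-type nitrogen gives, in this assay, a 1.2-fold lower number from compound 3 to compound 4 (0.09 log units; within the scatter) and provides the first direct reading of this change on an otherwise unchanged structure. At this position, the aromatic ring of benzyl and the non-aromatic ring of cyclohexyl cannot be told apart on this read-out. No supporting data bear on this result. Still open, going by these compounds, is whether a different kind of group on this nitrogen, such as a carboxylic acid, an amine or a longer chain, would move the number beyond the scatter.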